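The source may report more compounds than this note shows. Statements on the series, on what has been measured and on what is new or still open speak of the compounds shown alone.

For the measured compounds named here, in a functional assay on HCT-15 cells (Homo sapiens) (a lower number here means that less compound is needed, a higher number that more compound is needed for the effect), compound 1 `COc1cc(C2OC(c3ccc(N(C)C)cc3)=NN2C(C)=O)cc(OC)c1OC` gives 0.033 uM, while compound 2 `COc1cc(C2OC(c3ccc(N(C)C)cc3)=NN2C(=O)CN(C)C)cc(OC)c1OC` gives 80 uM, the higher of the two numbers so far. The next structure, compound 3 `COc1cc(C2OC(c3ccc(N(C)C)cc3)=NN2C(=O)CO)cc(OC)c1OC`, has hydroxy in place of dimethylamino on a saturated chain carbon bound to a carbonyl carbon.

Going by the values given here, only one measured step bears on this change. It is a 2400-fold higher number from compound 1 to compound 2 (3.38 log units; beyond the scatter), and it came with dimethylamino in place of hydrogen on that same saturated chain carbon. This step is large and beyond the scatter, so removing the dimethylamino may matter in this assay. However, no measurement yet shows how hydroxy behaves at this place, and hydroxy is not the hydrogen of compound 1. A large move towards a lower number is therefore expected, though not all the way back to the value of compound 1.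

The estimated change is a 53-fold lower number from compound 2 to compound 3 (1.73 log units; beyond the scatter). Compound 3 is expected at 1.5 uM, with an estimated range of 0.1 uM to 30 uM.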

Compound 3, concentration for half-maximal effect: 0.026 uM
Beside the measured number, compound 3's estimate is 58-fold (1.76 log units) above it; measured number below the stated range.
By their numbers in this assay, from the lowest: compounds 3 and 1 (each within the scatter of the next); then compound 2.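

In this assay, the place on the saturated chain carbon bound to a carbonyl carbon proves far more permissive than the earlier pair suggested, with a 3100-fold lower number from compound 2 to compound 3 (3.49 log units; beyond the scatter) once hydroxy replaces dimethylamino. Hydroxy and hydrogen at this place read alike, with a 1.3-fold lower number from compound 1 to compound 3 (0.10 log units; within the scatter) lying within the scatter, so a substituent here does not by itself carry the loss seen in a 2400-fold higher number from compound 1 to compound 2 (3.38 log units; beyond the scatter). Among the three groups shown, that loss therefore goes with dimethylamino alone, while compound 1 and compound 3 stand together at the low end of the series.

No measured information accounts for the wide gap between the hydroxy and dimethylamino compounds. From the compounds shown here alone, it remains open whether the loss follows the nitrogen or the whole dimethylamino group, which a primary amine at the same place would help to separate, and whether a methoxy group, a carboxylic acid or a longer chain carrying hydroxy would stay with compound 3 or move towards compound 2.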